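Halogen swap on the shared core: working notes

A few compounds are considered here, and "the series" means these few. Any claim that something is new, unique, unknown or untested is made for them only; others in the source may bear on it.

Measured so far:
compound 1, `OCC(CO)OCn1c(Cl)nc2c(Cl)c(Cl)ccc21`: > 100000 nM
compound 2, `OCC(CO)OCn1cnc2cc(Cl)c(Cl)cc21`: > 100000 nM
compound 3, `OCC(CO)OCn1c(Br)nc2c(Cl)cc(Cl)cc21`: > 100000 nM

In a functional assay on KB cells (Homo sapiens) for inhibition (on this read-out higher numbers stand for weaker inhibition and lower numbers for stronger inhibition), every entry so far is a limit of the assay and not a number. For compound 1 the entry > 100000 nM is such a limit. For compound 2 the entry > 100000 nM is likewise a limit. For compound 3 the entry > 100000 nM is again a limit. Going by the values given here, compound 1 therefore cannot be placed relative to the other two; all that is known is the limit of > 100000 nM in this assay, at which 3 of the 3 values shown sit, so no ordering among compounds 1, 2 and 3 can be read from these data, and no single-point step between measured compounds exists.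

Compound 4, `OCC(CO)OCn1c(Br)nc2c(Cl)c(Cl)ccc21`, differs from compound 1 by bromo in place of chloro on an aromatic carbon. Among the compounds with values here, with three limits and no measured step, the expectation for this change in this assay is no step beyond the scatter, most likely another limit. For compound 4 the estimated value is 100000 nM, range 50000 nM to 300000 nM, which is an expected step of a number no higher from compound 1 to compound 4 (the limit leaves the size open).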

Compound 4, half-maximal inhibitory concentration: > 100000 nM
Compound 4 gave a limit, no number; the forecaster's own chance of this, stated with the estimate: 90%; the middle value sits exactly at the limit.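

Compound 1 and compound 4, with bromo in place of chloro on an aromatic carbon, both end at a limit, so no step can be read between them: the limit of > 100000 nM in this assay, at which 4 of the 4 values shown sit.

The compounds shown leave open how bromo and chloro compare in this assay, and whether any halogen arrangement on the shared core gives a measurable value there.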